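Fluorine on the Benzamide Ring of Compound 2

A few compounds are considered here, and "the series" means these few. Any claim that something is new, unique, unknown or untested is made for them only; others in the source may bear on it.

Two compounds share a core built on a pyrazole bearing a phenyl group and a pyridine linked through an aminoalkyl chain. Compound 1 `COc1cccc(-c2nn(-c3ccccc3)cc2-c2ccnc(NCCNC(=O)Nc3cccc(C(F)(F)F)c3)c2)c1` carries a urea terminus and in a functional assay on cells (Panel CNS (Carcinoma cell lines), Homo sapiens) for antiproliferative activity (on this read-out lower numbers stand for stronger inhibition of growth and higher numbers for weaker inhibition of growth), gives 2070 nM. Compound 2 `O=C(NCCCNc1cc(-c2cn(-c3ccccc3)nc2-c2cccc(O)c2)ccn1)c1ccccc1` carries a benzamide terminus and in this assay gives 3600 nM. Of the two numbers that of compound 2 is the higher one, but the gap to compound 1 lies within the usual scatter, so the two compounds cannot be told apart on this read-out.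

Compound 3 `O=C(NCCCNc1cc(-c2cn(-c3ccccc3)nc2-c2cccc(O)c2)ccn1)c1ccc(F)cc1` differs from compound 2 in one place: fluoro in place of hydrogen on an aromatic carbon, so that the phenyl of the benzamide becomes a 4-fluorophenyl. Among the measured compounds shown here, no measured pair in this set shows a step of this kind, so nothing beyond the structures themselves guides the expectation. A single fluorine added to a distal aromatic ring is expected to produce no step beyond the scatter: the step from compound 2 to compound 3 is estimated as a 1.2-fold lower number from compound 2 to compound 3 (0.08 log units; within the scatter). Compound 3 is therefore expected to give 3000 nM, with a likely range from 1200 nM to 8000 nM.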

Compound 3, concentration for 50% growth inhibition: 3290 nM
Compound 3: the middle estimate sits 1.1-fold (0.04 log units) below what was measured, and the stated range covers the measured number.
By their numbers in this assay, from the lowest: compounds 1, 3 and 2 (each within the scatter of the next).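

Among the compounds shown here, with fluoro in place of hydrogen on the benzamide ring, para to a large group, this assay shows a 1.1-fold lower number from compound 2 to compound 3 (0.04 log units; within the scatter) and so gives the first step in this set that comes from a change in one place. The earlier pair, compound 1 and compound 2, differs in more than one place and could say nothing about this ring on its own, whereas here phenyl and 4-fluorophenyl can be set directly against each other and cannot be told apart on this read-out. At this one position, then, a single fluorine leaves the growth-inhibition number within the scatter, and no other measurement bears on this result.

The compounds shown leave open whether a different group at the same carbon, such as an amine, a nitrile or a carboxylic acid, would produce a step beyond the scatter, or whether fluoro would do so at another carbon of this ring. They also leave open whether the 4-fluorophenyl amide would read the same on a longer chain, since this one step comes from a single chain and a single terminus.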